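Moving the methoxy group on a urea-linked kinase inhibitor

The source may report more compounds than this note shows. Statements on the series, on what has been measured and on what is new or still open speak of the compounds shown alone.

Of the compounds shown here, three built on the same core have been tested in an assay on isolated protein for inhibition of proto-oncogene tyrosine-protein kinase receptor Ret (Homo sapiens), read by 33P incorporation, with stated times of 15 min and 40 min; a higher number here means a weaker inhibitor, a lower number a stronger inhibitor. Compound 1 `O=C(Nc1ccc(Cl)cc1)Nc1ccc(Nc2ncnc3c2OCCN3)cc1` carries a chloro group on its outer aromatic ring and gives 3070 nM. Compound 2 `O=C(Nc1ccc(Br)cc1)Nc1ccc(Nc2ncnc3c2OCCN3)cc1` has bromo in place of chloro on an aromatic carbon and gives 2220 nM; the step between them is a 1.4-fold lower number from compound 1 to compound 2 (0.14 log units; within the scatter). Compound 3 `COc1ccc(NC(=O)Nc2ccc(Nc3ncnc4c3OCCN4)cc2)cc1` has methoxy in place of the halogen and gives 227 nM, the lowest of the three numbers. The steps leading to it are a 14-fold lower number from compound 1 to compound 3 (1.13 log units; beyond the scatter) and a 9.8-fold lower number from compound 2 to compound 3 (0.99 log units; beyond the scatter), both clearly beyond the scatter.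

Compound 4 `COc1cccc(NC(=O)Nc2ccc(Nc3ncnc4c3OCCN4)cc2)c1` keeps every atom of compound 3 but joins them differently: 3-methoxyphenyl in place of 4-methoxyphenyl on an amide-type nitrogen. Going by the values given here, none of the measured steps moves a group from one place on the ring to another; each exchanges one substituent for another in the same place, so this change has no direct parallel. Because a 14-fold lower number from compound 1 to compound 3 (1.13 log units; beyond the scatter) and a 9.8-fold lower number from compound 2 to compound 3 (0.99 log units; beyond the scatter) show the methoxy compound at the lowest number, compound 4 is expected to remain closer to compound 3 than to the halogen compounds, though a modest weakening is plausible. Compound 4 is therefore estimated at 400 nM, within a range of 150 nM to 1200 nM. That would mean an expected step of a 1.8-fold higher number from compound 3 to compound 4 (0.25 log units; within the scatter) in this assay.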

Compound 4, half-maximal inhibitory concentration: 6810 nM
The estimate for compound 4 lay 17-fold (1.23 log units) below the measured number; the measured number lies above the stated range.
By their numbers in this assay, from the lowest: compound 3; then compounds 2 and 1 (each within the scatter of the next); then compound 4.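

Moving the methoxy group while keeping every atom gives a 30-fold higher number from compound 3 to compound 4 (1.48 log units; beyond the scatter) in this assay, so on this outer ring the place of a group can matter as much as the identity of the group. Compound 4 also falls behind both halogen compounds, with a 3.1-fold higher number from compound 2 to compound 4 (0.49 log units; beyond the scatter) and a 2.2-fold higher number from compound 1 to compound 4 (0.35 log units; beyond the scatter); a methoxy group therefore does not help wherever it sits, since 4-methoxyphenyl gives the strongest compound of the four and 3-methoxyphenyl the weakest. Nothing available here explains why this shift costs so much.

The compounds shown leave open whether chloro and bromo would respond to the same move as strongly as methoxy does, or whether this sensitivity belongs to methoxy alone. Going by these compounds, it also remains open whether a slightly longer ether such as ethoxy, or an amine such as dimethylamino, would match the methoxy group of compound 3 or lose strength as compound 4 does.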